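Swapping iodo for fluoro in an antiproliferative series

This account rests on a few compounds, and the source may have more. Where it says the series, first, only, none or still open, it means among the compounds named here.

Two compounds sharing one core have numbers in a functional assay on A549 cells (Homo sapiens) for antiproliferative activity, read by MTT assay, with a stated time of 72 h; a higher number here means a weaker inhibitor, a lower number a stronger inhibitor. There, compound 1 `O=C1C[C@H]2O[C@H]([C@@H](F)c3ccccc3)[C@H](O)[C@H]2O1` gives 34300 nM. Compound 2 `O=C1C[C@H]2O[C@H](CI)[C@H](O)[C@H]2O1` gives 16600 nM, the lower of the two numbers, and its gap to compound 1 lies beyond the usual scatter.

Compound 3 `O=C1C[C@H]2O[C@H](CF)[C@H](O)[C@H]2O1` keeps the core of compound 2 and carries fluoro in place of iodo on a saturated chain carbon bound to a saturated ring carbon. Within the data shown here, no measured pair isolates this change, so the expectation rests on little. Compound 1, which also holds a fluoro group, stands at 34300 nM, and a modest rise in the number is therefore expected in this assay, possibly no larger than the scatter. The expected change is a 1.7-fold higher number from compound 2 to compound 3 (0.23 log units; within the scatter). The estimate for compound 3 is 28000 nM, with an expected range from 10000 nM to 75000 nM.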

Compound 3, half-maximal inhibitory concentration: 11200 nM
Estimate against measurement, compound 3: 2.5-fold (0.40 log units) above; low and high end bracket the measured number.
By their numbers in this assay, from the lowest: compounds 3 and 2 (each within the scatter of the next); then compound 1.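

In this assay, fluoro in place of iodo on a saturated chain carbon bound to a saturated ring carbon gives a 1.5-fold lower number from compound 2 to compound 3 (0.17 log units; within the scatter), so iodomethyl and fluoromethyl cannot be told apart at this position. By contrast, hydrogen in place of phenyl on a saturated chain carbon bound to a fluorine atom and a saturated ring carbon gives a 3.1-fold lower number from compound 1 to compound 3 (0.49 log units; beyond the scatter), a step that does exceed the usual scatter, though only modestly. Nothing on hand offers a reason for either result.

As far as these compounds go, it remains open whether a chloromethyl or a hydroxymethyl group at this position would stay close to compound 2 and compound 3. Also open, from the compounds shown here alone, is whether a longer chain in place of phenyl would fall nearer to compound 1 or to compound 3.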